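Removing the (1-bromoethenyl)carbonyl from compound 3

A few compounds are considered here, and "the series" means these few. Any claim that something is new, unique, unknown or untested is made for them only; others in the source may bear on it.

- compound 1 `C=C(Br)C(=O)Nc1ccc(C(=O)/C=C/c2ccccc2)cc1`: 960 nM
- compound 2 `C=C(Br)C(=O)Nc1ccc(C(=O)/C=C/c2cccc(OC)c2)cc1`: 500 nM
- compound 3 `C=C(Br)C(=O)Nc1ccc(C(=O)/C=C/c2ccccc2OC)cc1`: 1300 nM

In a functional assay on HeLa cells (Homo sapiens) for antiproliferative activity, with a stated time of 48 h (a lower number here means a stronger inhibitor, a higher number a weaker inhibitor), compound 3 gives 1300 nM. Against its nearest neighbour the data show a 1.4-fold higher number from compound 1 to compound 3 (0.13 log units; within the scatter), and against its furthest a 2.6-fold higher number from compound 2 to compound 3 (0.41 log units; beyond the scatter). The next compound is compound 4 `COc1ccccc1/C=C/C(=O)c1ccc(N)cc1`, which differs by hydrogen in place of (1-bromoethenyl)carbonyl on a nitrogen on an aromatic ring. In words, this is hydrogen in place of (1-bromoethenyl)carbonyl on a nitrogen on an aromatic ring.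

Going by the values given here, none of the measured steps touches that nitrogen. Those two steps and a 1.9-fold lower number from compound 1 to compound 2 (0.28 log units; within the scatter) all concern the methoxy group, so they give no direct measure of this change. Among the compounds with values here, all three measured compounds carry the (1-bromoethenyl)carbonyl, and the data hold no example without it. The expectation therefore rests on the size of the change itself, which is larger than any methoxy change seen so far. Starting from compound 3 at 1300 nM, a clearly higher number is expected, well beyond the scatter. The estimated step is a 12-fold higher number from compound 3 to compound 4 (1.06 log units; beyond the scatter). Compound 4 is expected at 15000 nM, with an estimated range of 4000 nM to 60000 nM.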

Compound 4, half-maximal inhibitory concentration: 7800 nM
Compound 4: middle estimate off by 1.9-fold (0.28 log units), on the high side, within the range that was stated.
By their numbers in this assay, from the lowest: compounds 2, 1 and 3 (each within the scatter of the next, the first and the last beyond it); then compound 4.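

In this assay, going by these compounds alone, replacing the (1-bromoethenyl)carbonyl on the nitrogen with hydrogen gives a 6.0-fold higher number from compound 3 to compound 4 (0.78 log units; beyond the scatter), the first measured change at this position and the first comparison that shows the contribution of this group. Within the data shown here, this step is larger than any step printed among compound 1, compound 2 and compound 3, so this change shifts the number further than the methoxy changes do, although it is read here in only one pair. The data shown offer no evidence on what lies behind this shift.

The compounds shown leave open how much of the step belongs to the bromine and how much to the rest of the group, a question that an acetyl or a propenoyl without bromine on that nitrogen would address. Also open, from the compounds shown here alone, is whether the step keeps its size with the 3-methoxyphenyl of compound 2 or with the unsubstituted phenyl of compound 1.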